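Semicarbazide extension on the quinoline urea series: compound 4

The source may report more compounds than this note shows. Statements on the series, on what has been measured and on what is new or still open speak of the compounds shown alone.

Compound 2 `COc1cc(NC(C)CCCNC(=O)Nc2cccc(Cl)c2)c2ncccc2c1` carries a 3-chlorophenyl urea and gives 37000 nM in a functional assay on NCI-H460 cells (Homo sapiens) for inhibition, read by MTT assay, with a stated time of 72 h (on this read-out higher numbers stand for weaker inhibition and lower numbers for stronger inhibition), standing second highest of the three numbers measured. Its fluoro analogue, compound 1 `COc1cc(NC(C)CCCNC(=O)Nc2cccc(F)c2)c2ncccc2c1`, gives 24000 nM in this assay, and the step of a 1.5-fold higher number from compound 1 to compound 2 (0.19 log units; within the scatter) sits within the scatter. Compound 3 `COc1cc(NC(C)CCCNC(=O)NNC(=O)Nc2ccc(Cl)cc2)c2ncccc2c1`, in which the aryl group is moved out onto a carbamoylamino linker, gives 63000 nM in this assay; the step of a 1.7-fold higher number from compound 2 to compound 3 (0.23 log units; within the scatter) lies within the scatter, while the step of a 2.6-fold higher number from compound 1 to compound 3 (0.42 log units; beyond the scatter) is a modest loss.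

Compound 4 `COc1cc(NC(C)CCCNC(=O)NNC(=O)Nc2ccc(O)cc2)c2ncccc2c1` is not yet measured. The change from compound 2 is ((4-hydroxyphenyl)carbamoyl)amino in place of 3-chlorophenyl on an amide-type nitrogen. Going by the values given here, the step from compound 2 to compound 3 is the closest precedent and was small; no measured pair shows a hydroxy group in place of a chloro on the terminal ring, so that part of the change is unsupported. The expected step is therefore a 1.9-fold higher number from compound 2 to compound 4 (0.28 log units; within the scatter), a small move toward weaker inhibition. For compound 4 the estimate in this assay is 70000 nM, with a range of 30000 nM to 160000 nM.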

Compound 4, half-maximal inhibitory concentration: > 100000 nM
Compound 4 was reported as a limit; the forecaster's own chance of this, stated with the estimate: 25%; at least 1.4-fold (0.15 log units) between middle value and limit.
By their numbers in this assay, from the lowest: compounds 1, 2 and 3 (each within the scatter of the next, the first and the last beyond it). At a limit, above all of these: compound 4.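

Compound 4 is reported only as a limit in this assay, not as a number: the limit of > 100000 nM in this assay, at which 1 of the 4 values shown sits.

Even so, the change on this amide-type nitrogen now gives a step beyond the scatter from the aryl ureas, with an at least 2.7-fold higher number from compound 2 to compound 4 (0.43 log units; beyond the scatter) and an at least 4.1-fold higher number from compound 1 to compound 4 (0.61 log units; beyond the scatter), whereas the chloro-bearing compound 3 stayed within the scatter of compound 2. The hydroxy in place of chloro on the terminal ring gives an at least 1.5-fold higher number from compound 3 to compound 4 (0.20 log units; that floor lies within the scatter), so the limit does not settle whether this swap adds any real loss.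

As far as these compounds go, how much of the loss belongs to the carbamoylamino linker and how much to the hydroxy stays open. Also open, from the compounds shown here alone, is how an amine or a carboxylic acid on the terminal ring would read in this assay, with or without that linker.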